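Series notes on cell tolerance across three analogues

The compounds below may be only part of what the source reports. "The series", "measured", "known", "first", "only" and "open" are said of these compounds alone.

Compound 1 `CCCOc1nc(N)nc2c1ncn2/C=C1/CC1(CO)CO` in an ADME assay on MOLT-3 cells (Homo sapiens) for cytotoxicity, with a stated time of 7 days; a higher number here means that more compound is tolerated, a lower number that less compound is tolerated: > 20000 nM, a limit rather than a number.
Compound 2 `Nc1nc(NCc2ccccc2)c2ncn(/C=C3/CC3(CO)CO)c2n1` in this assay: > 20000 nM, likewise a limit rather than a number.

For the measured compounds named here, compound 2 stands at the limit of this assay, and the one further value shown is a limit as well. Going by the values given here, the only measured step, a step that the two limits leave unreadable from compound 1 to compound 2, has limits at both ends and so gives neither size nor direction. Compound 3 `CCCSc1nc(N)nc2c1ncn2/C=C1/CC1(CO)CO` differs from compound 2 as propylsulfanyl in place of benzylamino on an aromatic carbon. The propylsulfanyl chain recalls compound 1, which carries propoxy in the same series. Compound 1 gives only a limit, > 20000 nM. Given the shared limit, (the limit of > 20000 nM in this assay, at which 2 of the 2 values shown sit), compound 3 is expected to remain at the limit too, so that a step that the limit leaves unreadable from compound 2 to compound 3 is expected to be no step beyond the scatter. Compound 3 is therefore estimated at 30000 nM, within 15000 nM to 100000 nM.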

Compound 3, half-maximal cytotoxic concentration: > 20000 nM
Compound 3: a limit, no number (the forecaster's own chance of this, stated with the estimate: 85%); the middle value is on the limit's open side.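

In this assay compound 3 gives > 20000 nM as a limit, not a number. For the compounds shown here, no step among compound 1, compound 2 and compound 3 can be read: the limit of > 20000 nM in this assay, at which 3 of the 3 values shown sit.

The compounds shown leave open whether propoxy, benzylamino and propylsulfanyl differ at all in tolerated concentration beyond this limit.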